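The source may hold more compounds than are shown below. What is called first, only, known or untested is meant among the compounds shown, and "the series" means these compounds.

In a functional assay on MCF7 cells (Homo sapiens) for antiproliferative activity, read by MTT assay, with a stated time of 24 h (on this read-out lower numbers stand for stronger inhibition and higher numbers for weaker inhibition), three compounds on a shared core have been measured. Compound 1 `CCn1c(C(=O)N[C@@H](CC(=O)OC)C(=O)OC)ccc1C(CC)(CC)c1ccc(OCS(=O)(=O)c2ccccc2)c(C)c1` gives no number, only a limit (> 50000 nM). Compound 2 `CCn1c(C(=O)N[C@@H](C)CO)ccc1C(CC)(CC)c1ccc(OCS(=O)(=O)c2ccccc2)c(C)c1` reads 10800 nM and compound 3 `CCn1c(C(=O)NC(C)(C)CO)ccc1C(CC)(CC)c1ccc(OCS(=O)(=O)c2ccccc2)c(C)c1` reads 20700 nM on this scale, so these two stand together. Compound 4 `CCn1c(C(=O)N[C@@H](CO)C(C)C)ccc1C(CC)(CC)c1ccc(OCS(=O)(=O)c2ccccc2)c(C)c1` carries 1-(hydroxymethyl)-2-methylpropyl in place of 1-(hydroxymethyl)-1-methylethyl on an amide-type nitrogen. The closest guide is the swap between similar groups, a 1.9-fold higher number from compound 2 to compound 3 (0.28 log units; within the scatter) and so no real shift. The larger steps (an at least 4.6-fold lower number from compound 1 to compound 2 (0.66 log units; beyond the scatter); an at least 2.4-fold lower number from compound 1 to compound 3 (0.38 log units; beyond the scatter)) removed 1,2-bis(methoxycarbonyl)ethyl, a different kind of change, and bear less on this one. The expected change is therefore small (a 1.4-fold lower number from compound 3 to compound 4 (0.14 log units; within the scatter)) and not beyond the scatter. For compound 4 the estimate in this assay is 15000 nM with an expected range of 6000 nM to 40000 nM on this read-out.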

Compound 4, half-maximal inhibitory concentration: 18800 nM
The estimate for compound 4 lay 1.3-fold (0.10 log units) below the measured number; measured number inside the range.
By their numbers in this assay, from the lowest: compounds 2, 4 and 3 (each within the scatter of the next). At a limit, above all of these: compound 1.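

In this assay the group on the amide-type nitrogen can change to 1-(hydroxymethyl)-2-methylpropyl without a real shift: a 1.1-fold lower number from compound 3 to compound 4 (0.04 log units; within the scatter) and a 1.7-fold higher number from compound 2 to compound 4 (0.24 log units; within the scatter) both lie within the scatter. Compounds 2, 3 and 4, all carrying a hydroxymethyl group here, therefore stand together, and the added carbon neither gains nor loses anything measurable. Only an at least 2.6-fold lower number from compound 1 to compound 4 (0.42 log units; beyond the scatter) goes beyond the scatter, and its size is only a bound because compound 1 stands at a limit: the limit of > 50000 nM in this assay, at which 1 of the 4 values shown sits.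

Open, from the compounds shown here alone, is whether a carboxylic acid, an amine or a longer chain ending in hydroxyl on this nitrogen would move the number.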